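Clearance of hydroxy-acyl variants on a shared core

A few compounds are considered here, and "the series" means these few. Any claim that something is new, unique, unknown or untested is made for them only; others in the source may bear on it.

Compound 1, `O=C(NCc1cc(Cl)ccc1-n1cnnn1)[C@@H]1C[C@@H]2C[C@@H]2N1C(=O)[C@H](O)CC1CC1`: < 12 mL.min-1.g-1 in an ADME assay on liver for metabolic stability, with Liver microsome (Homo sapiens) as the target, read by LC-MS, using microsomes; on this read-out higher numbers stand for fast clearance and lower numbers for slow clearance
Compound 2, `O=C(NCc1cc(Cl)ccc1-n1cnnn1)[C@@H]1C[C@@H]2C[C@@H]2N1C(=O)[C@H](O)c1ccccc1`: < 16 mL.min-1.g-1 in this assay
Compound 3, `CC(C)(C)C[C@@H](O)C(=O)N1[C@H](C(=O)NCc2cc(Cl)ccc2-n2cnnn2)C[C@@H]2C[C@@H]21`: 40 mL.min-1.g-1 in this assay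

The three measured compounds share one core and differ only in the group on a saturated chain carbon bound to a carbonyl carbon and an oxygen on a saturated carbon. Compound 3 is the only one of the three with a number: the other two values are limits of the assay. For compound 1 the value is a limit, sitting at the limit of < 12 mL.min-1.g-1 in this assay, at which 1 of the 3 values shown sits. For compound 2 the value is likewise a limit, sitting at the limit of < 16 mL.min-1.g-1 in this assay, at which 1 of the 3 values shown sits. The step that the two limits leave unreadable from compound 1 to compound 2 therefore cannot be read. The two steps that can be read both lead to compound 3: an at least 3.3-fold higher number from compound 1 to compound 3 (0.52 log units; beyond the scatter), and an at least 2.5-fold higher number from compound 2 to compound 3 (0.39 log units; beyond the scatter). Compound 3 thus stands at the upper end of what has been shown.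

Compound 4, `O=C(NCc1cc(Cl)ccc1-n1cnnn1)[C@@H]1C[C@@H]2C[C@@H]2N1C(=O)[C@H](O)C1CCCCC1`, has not been measured in this assay. It differs from compound 3 as follows: cyclohexyl in place of neopentyl on a saturated chain carbon bound to a carbonyl carbon and an oxygen on a saturated carbon. For the measured compounds named here, neither measured step places a cyclohexyl group, and the one ring group measured, the phenyl of compound 2, gives only a limit. The nearest guide is that a cyclopropylmethyl and a phenyl both gave lower readings than the neopentyl of compound 3. A change back toward a lower reading, a 1.4-fold lower number from compound 3 to compound 4 (0.15 log units; within the scatter), is therefore expected, modest and not clearly beyond the scatter. Compound 4 is estimated at 28 mL.min-1.g-1, between 12 mL.min-1.g-1 and 70 mL.min-1.g-1.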

Compound 4, intrinsic clearance in microsomes: 150 mL.min-1.g-1
Beside the measured number, compound 4's estimate is 5.4-fold (0.73 log units) below it, outside the stated range (above it).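

At this position, on a saturated chain carbon bound to a carbonyl carbon and an oxygen on a saturated carbon, cyclohexyl in place of neopentyl gives a 3.8-fold higher number from compound 3 to compound 4 (0.57 log units; beyond the scatter) in this assay, so compound 3 no longer marks the upper end of the series and the group with the most carbon now reads highest. A ring at this position therefore does not by itself go with a low reading, since cyclohexyl in place of phenyl gives an at least 9.3-fold higher number from compound 2 to compound 4 (0.97 log units; beyond the scatter), a step whose size is only a minimum as it starts from a limit of the assay: the limit of < 16 mL.min-1.g-1 in this assay, at which 1 of the 4 values shown sits. The smallest group shown is left furthest behind, with cyclohexyl in place of cyclopropylmethyl giving an at least 12-fold higher number from compound 1 to compound 4 (1.09 log units; beyond the scatter), again a minimum that starts from a limit of the assay: the limit of < 12 mL.min-1.g-1 in this assay, at which 1 of the 4 values shown sits.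

The compounds shown leave open whether the high reading belongs to cyclohexyl alone or extends to a smaller saturated ring such as cyclopentyl. They also leave open how the reading would respond to a ring holding an oxygen, such as tetrahydropyran, or to an amine on the cyclohexyl ring.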